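Compound 3: methyl in place of hydrogen, aromatic carbon

The source may report more compounds than this note shows. Statements on the series, on what has been measured and on what is new or still open speak of the compounds shown alone.

For the measured compounds named here, in an ADME assay on microsomes from liver (Rattus norvegicus) for metabolic stability (on this read-out higher numbers stand for fast clearance and lower numbers for slow clearance), compound 1 `CNc1nc(NC2(C#N)CCCC(C)C2)nc(-n2cncn2)n1` gives 96 mL/min/kg and compound 2 `CNc1nc(NC2(C#N)CCCCC2)nc(-n2cncn2)n1` gives 52 mL/min/kg, so compound 2 stands within the scatter of the only other measured value. Compound 3 `CNc1nc(NC2(C#N)CCCCC2)nc(-n2cnc(C)n2)n1` differs from compound 2 by methyl in place of hydrogen on an aromatic carbon, turning 1H-1,2,4-triazol-1-yl into 3-methyl-1H-1,2,4-triazol-1-yl. Going by the values given here, only one measured step bears on this, and only loosely: a 1.8-fold lower number from compound 1 to compound 2 (0.27 log units; within the scatter). It also concerns a methyl, but on a saturated ring carbon, and it stays within the scatter. Among the compounds with values here, no measured step touches the five-membered aromatic ring. No step beyond the scatter is therefore expected in this assay, and the estimated step is a 1.2-fold higher number from compound 2 to compound 3 (0.06 log units; within the scatter). For compound 3 the expected value is 60 mL/min/kg, with an estimated range of 32 mL/min/kg to 110 mL/min/kg.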

Compound 3, clearance: > 276 mL/min/kg
Compound 3 ended at the assay's limit; the forecaster's own chance of this, stated with the estimate: 3%; at least 4.6-fold (0.66 log units) between middle value and limit.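

In this assay, the aromatic carbon between two ring nitrogen atoms is sensitive to a small change: methyl in place of hydrogen there gives an at least 5.3-fold higher number from compound 2 to compound 3 (0.72 log units; beyond the scatter). For the compounds shown here, the only earlier step, hydrogen in place of methyl on a saturated ring carbon, reads a 1.8-fold lower number from compound 1 to compound 2 (0.27 log units; within the scatter), so a methyl at that place stays within the scatter, while a methyl on the five-membered aromatic ring goes beyond it. The result for compound 3 is a limit of the assay and not a number, so the full size of the step cannot be read: the limit of > 276 mL/min/kg in this assay, at which 1 of the 3 values shown sits.

Going by these compounds, it remains open whether this shift is specific to methyl or would also appear with an ethyl, a methoxy or an amine on the same carbon. Also open, on these data alone, is whether the same change gives a similar step on compound 1, which carries the methyl on the saturated ring.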